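Bromophenyl placement in a tetrazole series on keratinocyte viability

The compounds below may be only part of what the source reports. "The series", "measured", "known", "first", "only" and "open" are said of these compounds alone.

Measured compounds:
compound 1, `COc1ccc(-n2nnnc2Nc2ccccc2Cl)cc1`, 134000 nM
compound 2, `COc1ccc(-n2nnnc2Nc2ccccc2Br)cc1`, 137000 nM

In an ADME assay on HaCaT cells (Homo sapiens) for cytotoxicity, read by MTT assay, with a stated time of 72 h (on this read-out lower numbers stand for stronger inhibition and higher numbers for weaker inhibition), compound 2 gives 137000 nM, the highest of the two numbers, with compound 1 within the scatter of it. Compound 3, `COc1ccc(-n2nnnc2Nc2ccc(Br)cc2)cc1`, differs from compound 2 by 4-bromophenyl in place of 2-bromophenyl on a nitrogen on an aromatic ring. For the measured compounds named here, the only measured step, a 1.0-fold higher number from compound 1 to compound 2 (0.01 log units; within the scatter), swaps halogens rather than rearranging the bromophenyl, so no step bears directly on this change. With no evidence that the arrangement matters, compound 3 is expected to sit within the scatter of compound 2, giving an expected step of a 1.1-fold lower number from compound 2 to compound 3 (0.02 log units; within the scatter). Compound 3 is estimated at 130000 nM, with a range from 60000 nM to 280000 nM.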

Compound 3, half-maximal inhibitory concentration: 131000 nM
Beside the measured number, compound 3's estimate is 1.0-fold (0.00 log units) below it; measured number inside the range.
By their numbers in this assay, from the lowest: compounds 3, 1 and 2 (each within the scatter of the next).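

In this assay, the 4-bromophenyl in place of 2-bromophenyl on a nitrogen on an aromatic ring gives a 1.0-fold lower number from compound 2 to compound 3 (0.02 log units; within the scatter), so a rearrangement of this group, and not only a swap of halogens, has now been tested at this place and stays within the scatter. The 4-bromophenyl in place of 2-chlorophenyl gives a 1.0-fold lower number from compound 1 to compound 3 (0.01 log units; within the scatter), also within the scatter. No supporting measurement accounts for this result. From the compounds shown here alone, whether an amine or a carboxylic acid in place of the bromine would give a step beyond the scatter remains open, as does the outcome of a longer chain elsewhere on the shared core.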